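The source may hold more compounds than are shown below. What is called first, only, known or untested is meant among the compounds shown, and "the series" means these compounds.

Two compounds of this series have been run so far. In a functional assay on RAW264.7 cells (Mus musculus) for inhibition (a higher number here means a weaker inhibitor, a lower number a stronger inhibitor), compound 1 `CC(C)(C)OC(=O)NC(=O)c1ccc(CN2C(=O)c3ccccc3S2(=O)=O)cc1` gives 64700 nM. Compound 2 `COC(=O)N(Cc1ccco1)C(=O)c1ccc(CN2C(=O)c3ccccc3S2(=O)=O)cc1` gives 76000 nM in this assay, the higher of the two numbers, but the gap to compound 1 lies within the scatter, so the two stand together as weak inhibitors and no ordering between them is claimed.

Compound 3 `CC(C)(C)OC(=O)N(Cc1ccco1)C(=O)c1ccc(CN2C(=O)c3ccccc3S2(=O)=O)cc1` is not yet measured. It differs from compound 2 by tert-butyl in place of methyl on an oxygen next to a carbonyl group. Within the data shown here, no measured pair isolates this change: compound 1 and compound 2 differ in two places at once, and their values are indistinguishable.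

With only that to go on, the step from compound 2 to compound 3 in this assay is expected to be small, a 1.1-fold lower number from compound 2 to compound 3 (0.04 log units; within the scatter), with no clear direction beyond the scatter. Compound 3 is therefore estimated at 70000 nM in this assay, within a range from 25000 nM to 200000 nM.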

Compound 3, half-maximal inhibitory concentration: 2610 nM
Compound 3: middle estimate off by 27-fold (1.43 log units), on the high side; measured number outside the range, below it.
By their numbers in this assay, from the lowest: compound 3; then compounds 1 and 2 (each within the scatter of the next).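

In this assay the oxygen next to a carbonyl group is a sensitive position: with (furan-2-yl)methyl on the amide-type nitrogen in both compounds, tert-butyl in place of methyl gives a 29-fold lower number from compound 2 to compound 3 (1.46 log units; beyond the scatter) (large). With tert-butyl on the oxygen in both compounds, (furan-2-yl)methyl in place of hydrogen on the amide-type nitrogen gives a 25-fold lower number from compound 1 to compound 3 (1.39 log units; beyond the scatter) (also large), so compound 3, which carries both groups, stands apart from compound 1 and compound 2, each of which lacks one of them. No measurement shown gives a reason for either step.

On these data alone, whether ethyl or isopropyl on that oxygen would give part of the step stays open. Also open, as far as these compounds go, is whether benzyl on the amide-type nitrogen could serve in place of (furan-2-yl)methyl.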